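Chloro in place of methoxy: expecting little change

The source may report more compounds than this note shows. Statements on the series, on what has been measured and on what is new or still open speak of the compounds shown alone.

Compound 3 `COc1ccc(-c2ccnc(C(=O)Nc3ccc(Oc4ccnc5[nH]ccc45)cc3)n2)cc1` gives 12400 nM in a functional assay on MCF7 cells (Homo sapiens) for cytotoxicity, read by MTT assay, with a stated time of 72 h; on this read-out lower numbers stand for stronger inhibition and higher numbers for weaker inhibition. Compound 1 `Cc1ccc(-c2ccnc(C(=O)Nc3ccc(Oc4ccnc5[nH]ccc45)cc3)n2)cc1` gives 6410 nM and compound 2 `O=C(Nc1ccc(Oc2ccnc3[nH]ccc23)cc1)c1nccc(-c2cccc(Cl)c2)n1` gives 10200 nM; both numbers lie within the scatter of compound 3, so the three cannot be told apart on this read-out. Compound 4 `O=C(Nc1ccc(Oc2ccnc3[nH]ccc23)cc1)c1nccc(-c2ccc(Cl)cc2)n1` differs from compound 3 by chloro in place of methoxy on an aromatic carbon. For the measured compounds named here, two measured steps bear directly on this change: a 1.9-fold higher number from compound 1 to compound 3 (0.29 log units; within the scatter) and a 1.2-fold higher number from compound 2 to compound 3 (0.08 log units; within the scatter); the remaining step, a 1.6-fold higher number from compound 1 to compound 2 (0.20 log units; within the scatter), is equally small. Every change on this ring seen here has stayed inside the scatter, so the step to compound 4 is expected to do the same: a 1.3-fold lower number from compound 3 to compound 4 (0.12 log units; within the scatter). Compound 4 is therefore estimated at 9500 nM, with a range from 4000 nM to 22000 nM.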

Compound 4, half-maximal inhibitory concentration: "not active" (no number reported)
Compound 4: no number reported, so the estimate cannot be set against anything.
By their numbers in this assay, from the lowest: compounds 1, 2 and 3 (each within the scatter of the next).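

For the compounds shown here, compound 4 is reported as "not active" without a number, so no step from compound 3 to compound 4 can be read. No measurement shown here accounts for this result. Still open, going by these compounds, is how the number in this assay responds to 4-chlorophenyl in place of 4-methoxyphenyl.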